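A few compounds are considered here, and "the series" means these few. Any claim that something is new, unique, unknown or untested is made for them only; others in the source may bear on it.

In a functional assay on L1210 cells (Mus musculus) for antiproliferative activity (on this read-out higher numbers stand for an effect only at larger amounts of compound and lower numbers for an effect already at smaller amounts), compound 1 `CCCCCCCO/N=C/c1cc(OC)c2c(c1OC)C(=O)C=CC2=O` gives 0.213 ug/mL, compound 2 `CCCCCO/N=C/c1cc(OC)c2c(c1OC)C(=O)C=CC2=O` gives 0.175 ug/mL and compound 3 `CCCCCCCO/N=C(\CCCCCC)c1cc(OC)c2c(c1OC)C(=O)C=CC2=O` gives 0.162 ug/mL. All three numbers lie within the scatter of one another, so compound 1 stands level with both. Compound 4 `CCCO/N=C/c1cc(OC)c2c(c1OC)C(=O)C=CC2=O` has not yet been measured. Its difference from compound 1 is hydrogen in place of butyl on a saturated chain carbon, three bonds along the chain from an oxygen on an unsaturated carbon, which also reads as heptyl to propyl. Within the data shown here, the one measured step that bears on this is a smaller change of the same kind, a 1.2-fold lower number from compound 1 to compound 2 (0.09 log units; within the scatter), and it stays within the scatter. Nothing measured covers a chain as short as propyl, so the expectation is uncertain, but no step beyond the scatter is expected in this assay. The estimated step is a 1.1-fold lower number from compound 1 to compound 4 (0.03 log units; within the scatter). For compound 4 the expected value is 0.2 ug/mL, with an estimated range of 0.1 ug/mL to 0.4 ug/mL.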

Compound 4, concentration for half-maximal effect: 0.107 ug/mL
Estimate against measurement, compound 4: 1.9-fold (0.27 log units) above, and the stated range covers the measured number.
By their numbers in this assay, from the lowest: compounds 4, 3, 2 and 1 (each within the scatter of the next).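

Compound 4 shows that, in this assay, the chain can be cut back as far as propyl with every step still within the scatter (a 2.0-fold lower number from compound 1 to compound 4 (0.30 log units; within the scatter); a 1.6-fold lower number from compound 2 to compound 4 (0.21 log units; within the scatter)). The earlier compounds shown here covered only the change from heptyl to pentyl, so hydrogen in place of butyl, three bonds along the chain from the oxygen, extends that reading to a much larger loss of chain. Nothing available explains this flat response. From the compounds shown here alone, whether the same holds for an amine or a carboxylic acid in place of the propyl chain remains open.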